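Anilinothiazole enones on Bel-7402 cells: limits so far

This account rests on a few compounds, and the source may have more. Where it says the series, first, only, none or still open, it means among the compounds named here.

Measured compounds, each giving only a limit of the assay:
- compound 1 `COc1cccc(/C=C/C(=O)c2sc(Nc3cccc(C)c3)nc2C)c1`: > 25000 nM
- compound 2 `COc1cccc(/C=C/C(=O)c2sc(Nc3ccccc3)nc2C)c1`: > 25000 nM
- compound 3 `Cc1nc(Nc2ccccc2)sc1C(=O)/C=C/c1ccccc1Cl`: > 25000 nM

In a functional assay on Bel-7402 cells (Homo sapiens) for cytotoxicity, read by MTT assay (a higher number here means a weaker inhibitor, a lower number a stronger inhibitor), compound 2 gives > 25000 nM, a limit of the assay and not a number. Compound 1 in this assay likewise gives > 25000 nM, again a limit. For compound 3 the read-out in this assay is > 25000 nM, also a limit. All three readings sit at the limit of > 25000 nM in this assay, at which 3 of the 3 values shown sit.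

The change from compound 2 to compound 1 is methyl in place of hydrogen on an aromatic carbon, and its step, a step that the two limits leave unreadable from compound 2 to compound 1, cannot be sized because both values are limits. The cores of compound 2 and compound 3 differ by 2-chlorophenyl in place of 3-methoxyphenyl on a double-bonded chain carbon bound to a double-bonded chain carbon; the step that the two limits leave unreadable from compound 2 to compound 3 is equally unreadable.

Compound 4 `Cc1ccc(Nc2nc(C)c(C(=O)/C=C/c3ccccc3Cl)s2)cc1` is not yet measured. It differs from compound 3 by methyl in place of hydrogen on an aromatic carbon. This is the same kind of change as that from compound 2 to compound 1, not the same: in the earlier pair the methyl enters meta to a large group, here it enters para to a large group, and the two pairs stand on different cores, as told by 2-chlorophenyl in place of 3-methoxyphenyl on a double-bonded chain carbon bound to a double-bonded chain carbon.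

With every reading so far a limit, the step from compound 3 to compound 4 is expected to be small or itself unreadable, a step that the limit leaves unreadable from compound 3 to compound 4, resting on compound 3 showing > 25000 nM and on the unsized step that the two limits leave unreadable from compound 2 to compound 1. Compound 4 is therefore estimated to give around 30000 nM in this assay, most likely reported again as a limit, with a range from 10000 nM to 100000 nM.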

Compound 4, half-maximal inhibitory concentration: > 25000 nM
Compound 4: no number, only a limit; the forecaster's own chance of this, stated with the estimate: 80%; the middle value lies beyond the limit too.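

No new step can be read: compound 3 and compound 4 both give only limits of the assay, so the methyl change between them cannot be sized, and the series stands as before: the limit of > 25000 nM in this assay, at which 4 of the 4 values shown sit.

The compounds shown leave open whether any change on the shared core alters the reading in this assay, and what number any of these four compounds would give.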